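The source may report more compounds than this note shows. Statements on the series, on what has been measured and on what is new or still open speak of the compounds shown alone.

Measured so far:
compound 1 `Nc1nnc(-c2csc(-c3ccccc3)n2)o1`: 25.5%
compound 2 `S=c1[nH]nc(-c2csc(-c3ccccc3)n2)o1`: 53.8%

Going by the values given here, in a functional assay on the whole organism (strain Wistar albino) for inhibition, with Rattus norvegicus as the target, read by paw edema, with stated times of 1 h and 2 h, at a dose of 25 mg/kg by the oral route (a lower number here means less inhibition, a higher number more inhibition at the dose given (going by the name of the read-out)), compound 1 gives 25.5%, the lower of the two numbers so far, while compound 2 gives 53.8%, a gap beyond the usual scatter. Compound 3 `c1ccc(-c2nc(-c3nnco3)cs2)cc1` has not yet been tested. It differs from compound 1 by hydrogen in place of amino on an aromatic carbon. Among the compounds with values here, no measured pair shows what taking away this group does, so only a small shift, slightly downward, is expected. The expected step of a number 3.5 percentage points lower from compound 1 to compound 3 (within the scatter) would keep compound 3 near the low end. Compound 3 is estimated at 22%, between 8% and 38%.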

Compound 3, a percentage reported as inhibition, in the whole organism at one dose (the size of the read-out at that dose, not a potency): 31.5%
The estimate for compound 3 lay 9.5 percentage points below the measured number; measured number inside the range.
By their numbers in this assay, from the lowest: compounds 1 and 3 (each within the scatter of the next); then compound 2.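

The change from amino to hydrogen on this aromatic carbon gives a number 6 percentage points higher from compound 1 to compound 3 (within the scatter) in this assay, so at the dose given this read-out does not separate the two groups at this position. Compound 1 and compound 3 therefore show that an amino group here makes no difference beyond the scatter. No measurement at hand offers a reason for this result. Still open, on these data alone, is whether a methyl group, a carboxylic acid or a longer chain on this carbon would stand apart from both amino and hydrogen.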